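Heteroaryl swaps on the methoxyphenyl sulfonamide series

A few compounds are considered here, and "the series" means these few. Any claim that something is new, unique, unknown or untested is made for them only; others in the source may bear on it.

Measured so far:
compound 1 `COc1ccc(-c2cc(C(=O)N(C)C)ccn2)cc1S(=O)(=O)Nc1cccc(NCCNC(=O)c2cccc(C)c2)c1`: 1810 nM
compound 2 `COc1ccc(-c2ccnc(C(=O)N(C)C)c2)cc1S(=O)(=O)Nc1cccc(NCCNC(=O)c2cccc(C)c2)c1`: 5170 nM
compound 3 `COc1ccc(-c2csc(C(=O)N(C)C)c2)cc1S(=O)(=O)Nc1cccc(NCCNC(=O)c2cccc(C)c2)c1`: 1330 nM

All three numbers come from a functional assay on CHO-RD-HGA16 cells for agonist activity at Orexin/Hypocretin receptor type 1 (Homo sapiens), read by fluorescence and calcium flux, with a stated time of 30 min; on this read-out lower numbers stand for an effect already at smaller amounts and higher numbers for an effect only at larger amounts of compound. Compound 3 has the lowest number of the three; its nearest neighbour differs by a 1.4-fold lower number from compound 1 to compound 3 (0.13 log units; within the scatter), its furthest by a 3.9-fold lower number from compound 2 to compound 3 (0.59 log units; beyond the scatter). Compound 4 `COc1ccc(-c2csc(C(=O)N(C)C)n2)cc1S(=O)(=O)Nc1cccc(NCCNC(=O)c2cccc(C)c2)c1` carries 2-(dimethylcarbamoyl)-1,3-thiazol-4-yl in place of 5-(dimethylcarbamoyl)thiophen-3-yl on an aromatic carbon. Among the compounds with values here, no measured step mirrors this exact change; the only precedent is that exchanges among the heteroaryl groups of compounds 1, 2 and 3 moved the read-out by a 2.9-fold higher number from compound 1 to compound 2 (0.46 log units; beyond the scatter) at most. A step of similar or smaller size is therefore expected in this assay, direction uncertain. Compound 4 is estimated at 1800 nM (range 600 nM to 5500 nM). The expected step is a 1.4-fold higher number from compound 3 to compound 4 (0.13 log units; within the scatter).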

Compound 4, half-maximal effective concentration: 928 nM
Compound 4: middle estimate off by 1.9-fold (0.29 log units), on the high side, and the stated range covers the measured number.
By their numbers in this assay, from the lowest: compounds 4, 3 and 1 (each within the scatter of the next); then compound 2.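

The 2-(dimethylcarbamoyl)-1,3-thiazol-4-yl group gives a 1.4-fold lower number from compound 3 to compound 4 (0.16 log units; within the scatter) against the 5-(dimethylcarbamoyl)thiophen-3-yl group, so a second hetero atom in the five-membered ring is tolerated at this position. The same group gives a 2.0-fold lower number from compound 1 to compound 4 (0.29 log units; within the scatter) and a 5.6-fold lower number from compound 2 to compound 4 (0.75 log units; beyond the scatter), leaving only compound 2 apart from the other three compounds. Nothing at hand explains these differences.

Going by these compounds, whether a carboxylic acid or a primary amide could replace the dimethylcarbamoyl group on the 1,3-thiazol-4-yl ring stays open. So does the effect of a pyrazole or an oxazole ring at this position.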